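Working notes: the aromatic substituent of compound 2

The source may report more compounds than this note shows. Statements on the series, on what has been measured and on what is new or still open speak of the compounds shown alone.

Measured so far in an ADME assay on microsomes from liver (Rattus norvegicus) for metabolic stability, using NADPH, with a stated time of 10 min; on this read-out lower numbers stand for a less stable compound and higher numbers for a more stable compound
- compound 1 `CN(C[C@H]1Cc2c(cccc2N2C[C@H]3CNC[C@H]3C2)CN1)[C@H]1CCCc2cccnc21` gives 38.1%
- compound 2 `CN(C)[C@@H]1CCN(c2cccc3c2C[C@H](CN(C)[C@H]2CCCc4cccnc42)NC3)C1` gives 3.88%
- compound 3 `CN1CCN(Nc2cccc3c2C[C@@H](CN(C)[C@H]2CCCc4cccnc42)NC3)CC1` gives 21%

Compound 2 stands lowest of the three at 3.88% and both other values lie beyond the scatter above it. The unmeasured compound 4 `CN(C[C@H]1Cc2c(cccc2N[C@H]2CC[C@H](N)CC2)CN1)[C@H]1CCCc2cccnc21` differs from it by (4-aminocyclohexyl)amino in place of 3-(dimethylamino)pyrrolidin-1-yl on an aromatic carbon and the change falls on an aromatic carbon of a six-membered aromatic ring of carbon only.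

Within the data shown here, one measured step bears on this place. It is a number 34.2 percentage points lower from compound 1 to compound 2 (beyond the scatter) and it is large, so an exchange of groups on this aromatic carbon can shift the read-out well beyond the scatter. Among the measured compounds shown here, no measured compound carries the entering group, so the direction rests on the other values: compound 1 at 38.1% and compound 3 at 21% both lie higher than compound 2 does.

A rise is therefore expected, estimated as a number 18.1 percentage points higher from compound 2 to compound 4 (beyond the scatter) and smaller than the step described before. For compound 4 the estimated value is 22% with an expected range from 7% to 45% as a working figure.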

Compound 4, percent of the compound remaining: 75%
The estimate for compound 4 lay 53 percentage points below the measured number; the measured number lies above the stated range.
By their numbers in this assay, from the lowest: compound 2; then compound 3; then compound 1; then compound 4.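

In this assay, among these compounds, this aromatic carbon proves far more responsive than the earlier compounds showed: with the heavy-atom count unchanged, a number 71.1 percentage points higher from compound 2 to compound 4 (beyond the scatter). The entering (4-aminocyclohexyl)amino group also surpasses the group with two five-membered non-aromatic rings, a number 36.9 percentage points higher from compound 1 to compound 4 (beyond the scatter), so the earlier top value at this position is no upper bound for the series. Nothing available here accounts for the rise.

Open, as far as these compounds go, is which part of the entering group carries the change, as the six-membered carbon ring, the amino link to the aromatic carbon and the terminal primary amine all arrive together. A 4-hydroxycyclohexylamino group, with a hydroxyl in place of that amine, or a 4-aminopiperidin-1-yl group, bonded through its ring nitrogen, would begin to separate these parts.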